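Imidazole in place of the ring-bearing alkene side chain

The source may report more compounds than this note shows. Statements on the series, on what has been measured and on what is new or still open speak of the compounds shown alone.

Measured compounds:
compound 1 `CC(C)C(c1ccc(-c2ccc3cccc(F)c3c2)[nH]c1=O)N1CCNC1=O` with 9.1 nM
compound 2 `CC(C)C(/C=C1/CCNC1=O)c1ccc(-c2ccc3cccc(F)c3c2)[nH]c1=O` with 5.3 nM

In an assay on CHO cells for displacement of a labelled ligand from prostaglandin E2 receptor EP3 subtype (Homo sapiens), read by radioligand binding (on this read-out lower numbers stand for stronger inhibition and higher numbers for weaker inhibition), compound 2 gives the lower of the two numbers, but the step between the two measured compounds is only a 1.7-fold lower number from compound 1 to compound 2 (0.23 log units; within the scatter), so the two cannot be told apart on these data. For the measured compounds named here, the one step seen so far exchanged, on a saturated chain carbon bound to an aromatic carbon and a saturated chain carbon, a five-membered non-aromatic ring with two hetero atoms for a five-membered non-aromatic ring with one hetero atom, and it moved the number by no more than the usual scatter.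

Compound 3 `Cc1c[nH]c(C(c2ccc(-c3ccc4cccc(F)c4c3)[nH]c2=O)C(C)C)n1` has not been measured. It differs from compound 2 by a group of 6 heavy atoms (4 carbon, 2 nitrogen; one five-membered aromatic ring with 2 hetero atoms) in place of a group of 7 heavy atoms (5 carbon, 1 nitrogen, 1 oxygen; one five-membered non-aromatic ring with 1 hetero atom), on a saturated chain carbon bound to an aromatic carbon and a saturated chain carbon. The same position is touched as in the step from compound 1 to compound 2, and that step stayed within the scatter, so the expected movement in this assay from compound 2 to compound 3 is small, a 1.5-fold higher number from compound 2 to compound 3 (0.18 log units; within the scatter), with no clear direction. Compound 3 is therefore estimated at 8 nM, within a range of 2.5 nM to 30 nM.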

Compound 3, inhibition constant: 12 nM
The estimate for compound 3 lay 1.5-fold (0.18 log units) below the measured number; low and high end bracket the measured number.
By their numbers in this assay, from the lowest: compounds 2, 1 and 3 (each within the scatter of the next, the first and the last beyond it).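

In this assay the position proves open to a change of ring type, not only to an exchange of one non-aromatic ring for another: the 4-methyl-1H-imidazol-2-yl group, a five-membered aromatic ring, stands on the saturated chain carbon and the compound keeps a measurable affinity in the same low range. For the compounds shown here, measured against the ring-bearing alkene side chain, the change gives a 2.3-fold higher number from compound 2 to compound 3 (0.35 log units; beyond the scatter) and is the first step at this position to pass the usual scatter, though only modestly; measured against the 2-oxoimidazolidin-1-yl group, it gives a 1.3-fold higher number from compound 1 to compound 3 (0.12 log units; within the scatter) and stays within the scatter, so the three groups differ little and only one of the three pairs can be told apart. Nothing in the available data accounts for the modest loss seen from the alkene side chain to the imidazole.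

The compounds shown leave open what the methyl group on the imidazole contributes, which the unsubstituted 1H-imidazol-2-yl group would settle. They also leave open whether a six-membered aromatic ring such as pyridin-2-yl, or an open-chain amine or carboxylic acid, would be accepted on this same carbon.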